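The source may report more compounds than this note shows. Statements on the series, on what has been measured and on what is new or still open speak of the compounds shown alone.

Measured compounds in a functional assay, tested at 100 ug/mL; a lower number here means a weaker effect, a higher number a stronger effect of the compound at the concentration tested:
compound 1 `COc1ccc(C2=NN(c3ccccc3)C(c3ccc(C)cc3)C2S(=O)(=O)CC2=NCCO2)cc1` gives 67.7%;
compound 3 `COc1ccc(C2=NN(c3ccccc3)C(c3ccc(C)cc3)C2S(=O)(=O)CC2=NCCS2)cc1` gives 47.9%;
compound 2 `O=S(=O)(CC1=NCCS1)c1c(-c2ccc(Cl)cc2)noc1-c1ccc(Cl)cc1` is reported as "not active" (no number reported), with no number given.

Compound 1 and compound 3 share one core, compound 2 has another; the difference between the two cores is not broken down here. Within the first core, the step of a number 19.8 percentage points higher from compound 3 to compound 1 (beyond the scatter) comes from one change, (a group of 5 heavy atoms (3 carbon, 1 nitrogen, 1 oxygen; one five-membered non-aromatic ring with 2 hetero atoms) in place of a group of 5 heavy atoms (3 carbon, 1 nitrogen, 1 sulfur; one five-membered non-aromatic ring with 2 hetero atoms), on a saturated chain carbon bound to a sulfonyl sulfur). Compound 4 `O=S(=O)(CC1=NCCO1)c1c(-c2ccc(Cl)cc2)noc1-c1ccc(Cl)cc1` carries the same change on the core of compound 2: a group of 5 heavy atoms (3 carbon, 1 nitrogen, 1 oxygen; one five-membered non-aromatic ring with 2 hetero atoms) in place of a group of 5 heavy atoms (3 carbon, 1 nitrogen, 1 sulfur; one five-membered non-aromatic ring with 2 hetero atoms), on a saturated chain carbon bound to a sulfonyl sulfur. Since compound 2 gives no number, the step from compound 2 to compound 4 cannot be set beside the earlier one directly. Among the compounds with values here, what can be expected rests on the single earlier step of a number 19.8 percentage points higher from compound 3 to compound 1 (beyond the scatter) and on the report that compound 2 shows no activity. Compound 4 is therefore expected to give 25% in this assay, most likely between 5% and 50%, with a real chance that it, too, is reported only as not active.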

Compound 4, a percentage reported as activity, at one concentration (the size of the read-out at that concentration, not a potency): "not active" (no number reported)
Compound 4 has no reported number here; no gap can be computed for the estimate.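

In this assay compound 2 and compound 4 are both reported as not active, without a number, so no step can be read between them. The compounds shown leave open whether the oxygen-for-sulfur ring exchange has any effect on this core, as it does on the core of compound 1. No evidence given here bears on this result.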